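Swapping an Ester for an Ether on a Shared Core

The compounds below may be only part of what the source reports. "The series", "measured", "known", "first", "only" and "open" are said of these compounds alone.

Two close relatives have been tested in a functional assay on DLD-1 cells (Homo sapiens) for cytotoxicity, with a stated time of 48 h; a lower number here means a stronger inhibitor, a higher number a weaker inhibitor. Compound 1 `CCCC(=O)Oc1ccc2oc(/C=C/[S+](C)[O-])cc(=O)c2c1` gives 8700 nM, and compound 2 `COc1cccc2c(=O)cc(/C=C/[S+](C)[O-])oc12` gives 9000 nM. The number for compound 1 is the lower of the two, yet compound 2 sits within the scatter of it, so the pair cannot be told apart on these data. Compound 3 `CCCOc1ccc2oc(/C=C/[S+](C)[O-])cc(=O)c2c1` has not yet been measured. It differs from compound 1 in one place: propyl in place of propylcarbonyl on an oxygen on an aromatic ring. Going by the values given here, no measured pair shows a change of this kind, so no step of known size points the way. The two measured values lie close together on the same shared core, and nothing in them hints at a large effect of this change, so compound 3 is expected to land near 9000 nM, within 3000 nM to 27000 nM. The expected step of a 1.0-fold higher number from compound 1 to compound 3 (0.01 log units; within the scatter) is therefore none beyond the scatter.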

Compound 3, half-maximal inhibitory concentration: 6200 nM
Compound 3: middle estimate off by 1.5-fold (0.16 log units), on the high side; the measured number falls inside the stated range.
By their numbers in this assay, from the lowest: compounds 3, 1 and 2 (each within the scatter of the next).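

In this assay, replacing propylcarbonyl with propyl on the oxygen on an aromatic ring gives a 1.4-fold lower number from compound 1 to compound 3 (0.15 log units; within the scatter). Going by these compounds alone, this is the first step measured at this position, and it shows that the carbonyl can be removed from the (propylcarbonyl)oxy group without moving the number beyond the scatter, so the propoxy and (propylcarbonyl)oxy forms cannot be told apart on these data. No evidence is available that bears on why the two groups read alike.

The compounds shown leave open whether a longer chain on this oxygen, or a chain ending in an amine or a carboxylic acid, would stay in this range or move beyond the scatter. They also leave open how a free hydroxyl at this place would compare with the propoxy group.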